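A few compounds are considered here, and "the series" means these few. Any claim that something is new, unique, unknown or untested is made for them only; others in the source may bear on it.

In an ADME assay on microsomes from liver (Homo sapiens) for metabolic stability, read by LC-MS, with NADPH named in the record, with a stated time of 60 min, tested at 1 uM, in the absence of a further agent (on this read-out lower numbers stand for a less stable compound and higher numbers for a more stable compound), compound 1 `CC(=O)N[C@@H]1CCN(c2cc(C)nn3c(-c4nccs4)c(C)nc23)C1` gives > 95%, which is a limit of the assay and not a number. Compound 2 `COc1ccc(-c2c(C)nc3c(N4CC[C@@H](NC(=O)Oc5cccc(C)c5)C4)cc(C)nn23)cc1OC` likewise gives > 95%, again a limit. Compound 3 `COc1ccc(-c2c(C)nc3c(N4CC[C@@H](NC(=O)Oc5ccc6ccccc6c5)C4)cc(C)nn23)cc1OC` gives > 95%, also a limit. The step that the two limits leave unreadable from compound 2 to compound 3 therefore cannot be read in size. On the numbers shown, compound 2 stands at a limit, as the limit of > 95% in this assay, at which 3 of the 3 values shown sit, records. Compound 4 `COc1ccc(-c2c(C)nc3c(N4CC[C@@H](n5cc(-c6ccccc6)nn5)C4)cc(C)nn23)cc1OC` carries 4-phenyl-1H-1,2,3-triazol-1-yl in place of ((3-methylphenoxy)carbonyl)amino on a saturated ring carbon. For the measured compounds named here, no measured step bears on this change; the only step known is unreadable. Compound 4 is therefore expected to remain near the same limit, with a number at least 3 percentage points lower from compound 2 to compound 4 (that floor lies within the scatter) expected to be within the scatter. The estimate for compound 4 is 92%, from 78% to 99%.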

Compound 4, percent of the compound remaining: "unstable" (no number reported)
The entry for compound 4 holds no number, so the estimate cannot be set against anything.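

No step can be read from compound 2 to compound 4: compound 4 is recorded as unstable with no number, and compound 2 holds only a limit. The compounds shown leave open how large any change is on exchanging ((3-methylphenoxy)carbonyl)amino for 4-phenyl-1H-1,2,3-triazol-1-yl.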